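Swapping a Dichlorophenoxy Group for a Fluorophenylsulfanyl Group

The compounds below may be only part of what the source reports. "The series", "measured", "known", "first", "only" and "open" are said of these compounds alone.

Measured compounds:
compound 1 `Nc1cc(N)c2nc(-c3ccccc3)c(Oc3ccc(Cl)c(Cl)c3)nc2c1` — 64600 nM
compound 2 `COc1ccc(CNc2nc3cc(N)cc(N)c3nc2-c2ccccc2)cc1OC` — < 100000 nM

Of the compounds shown here, two have been tested in a functional assay on SF-539 cells (Homo sapiens) for inhibition, read by sulforhodamine B assay, with a stated time of 48 h; a lower number here means that less compound is tolerated, a higher number that more compound is tolerated. For the measured compounds named here, compound 1 is the only one with a number: in this assay compound 1 gives 64600 nM. The value reported for compound 2 is a limit of the assay rather than a number, and (the limit of < 100000 nM in this assay, at which 1 of the 2 values shown sits). Going by the values given here, no pair of measured compounds differs in a single place, so no step between measured compounds can be stated, and compound 1 stands alone as the sole point of reference.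

Compound 3 `Nc1cc(N)c2nc(-c3ccccc3)c(Sc3ccc(F)cc3)nc2c1` is not yet measured. It differs from compound 1 in one place: (4-fluorophenyl)sulfanyl in place of 3,4-dichlorophenoxy on an aromatic carbon. The aryl ring remains on the same carbon of the shared core, with the halogen pattern of the ring and the linking atom exchanged.

Among the compounds with values here, with no measured step to lean on, the change from compound 1 to compound 3 is expected to fall within the usual scatter, with no direction favoured. Compound 3 is therefore estimated at 55000 nM, between 15000 nM and 150000 nM, a step of a 1.2-fold lower number from compound 1 to compound 3 (0.07 log units; within the scatter) from the reference.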

Compound 3, concentration lethal to 50% of the cells: 75900 nM
Beside the measured number, compound 3's estimate is 1.4-fold (0.14 log units) below it, and the stated range covers the measured number.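

In this assay, the series now has its first measured step at this position, next to the ring nitrogen and ortho to a phenyl group: a 1.2-fold higher number from compound 1 to compound 3 (0.07 log units; within the scatter). The change from 3,4-dichlorophenoxy to (4-fluorophenyl)sulfanyl exchanges the linking atom and the halogen pattern of the ring together, yet the two compounds cannot be told apart in this read-out. For the compounds shown here, at this position, then, an aryl ring joined through sulfur with a single fluorine reads the same as one joined through oxygen with two chlorines, although the single step cannot show what either exchange does alone.

Compound 2 is reported only as a limit of the assay and not as a number, which leaves its place in the series open: the limit of < 100000 nM in this assay, at which 1 of the 3 values shown sits. The compounds shown also leave open how the linking atom and the halogens would each read if exchanged separately, and whether a group of another kind at this position, such as a morpholine ring or a carboxylic acid on the aryl ring, would move the number in this assay.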